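Replacing isoquinolin-3-yl with 1,3-benzothiazol-2-yl in compound 3

This account rests on a few compounds, and the source may have more. Where it says the series, first, only, none or still open, it means among the compounds named here.

In an ADME assay on microsomes from liver (Homo sapiens) for metabolic stability, read by LC-MS, with a stated time of 10 min, tested at 0.5 uM (a higher number here means that more of the compound is left, a lower number that less of the compound is left), compound 3 (`c1cnc2c(c1)CCC[C@@H]2N(CCCN1CCNCC1)Cc1cc2ccccc2cn1`) gives 66% and so sits level with compound 2 (`c1ccc2c(c1)CN[C@@H](CN(CCC1CCNCC1)[C@H]1CCCc3cccnc31)C2`) at 66% and within the scatter of compound 1 (`c1ccc2c(c1)CN[C@@H](CN(CC[C@@H]1CCCNC1)[C@H]1CCCc3cccnc31)C2`) at 75% in this small set. Compound 4 (`c1cnc2c(c1)CCC[C@@H]2N(CCCN1CCNCC1)Cc1nc2ccccc2s1`) differs from compound 3 in one place: 1,3-benzothiazol-2-yl stands in place of isoquinolin-3-yl on a saturated chain carbon bound to an amine nitrogen (1,3-benzothiazol-2-yl in place of isoquinolin-3-yl on a saturated chain carbon bound to an amine nitrogen). For the measured compounds named here, the only measured step is a number 9 percentage points lower from compound 1 to compound 2 (within the scatter) and it exchanges piperidin-3-yl for piperidin-4-yl elsewhere, so it offers no direct guide to this exchange. The expected step is a number 4 percentage points lower from compound 3 to compound 4 (within the scatter) in this assay and thus none beyond the scatter. Compound 4 is estimated at 62% (expected range 42% to 80%).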

Compound 4, percent of the compound remaining: 50%
Estimate against measurement, compound 4: 12 percentage points above; the range from low to high includes it.
By their numbers in this assay, from the lowest: compound 4; then compounds 2, 3 and 1 (each within the scatter of the next).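

In this assay, for the compounds shown here, 1,3-benzothiazol-2-yl in place of isoquinolin-3-yl on a saturated chain carbon bound to an amine nitrogen gives a number 16 percentage points lower from compound 3 to compound 4 (beyond the scatter), the only step in this set beyond the scatter. This place therefore responds to a change of group in a way that the exchange of piperidin-3-yl for piperidin-4-yl did not show. Nothing available accounts for this step.

This single exchange alters both ring size and ring atoms, so it cannot separate the two. The compounds also leave open how 1,3-benzoxazol-2-yl or quinolin-2-yl would stand at this place.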